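Cytotoxicity outlook for a hydroxyphenyl analogue

This account rests on a few compounds, and the source may have more. Where it says the series, first, only, none or still open, it means among the compounds named here.

Compound 2 `Cc1ccccc1-c1nnc(-c2sc(-c3cccnc3)nc2C)o1` is one of two measured compounds. In an ADME assay on HCT-116 cells (Homo sapiens) for cytotoxicity, read by MTT assay (a lower number here means that less compound is tolerated, a higher number that more compound is tolerated), compound 2 gives > 100 ug/mL, a limit of the assay rather than a number. Compound 1 `Cc1nc(-c2cccnc2)sc1-c1nnc(Cc2ccccc2)o1` also stops at a limit: in this assay compound 1 gives > 100 ug/mL. Within the data shown here, the step that the two limits leave unreadable from compound 1 to compound 2 therefore cannot be sized, and the only evidence is the limit of > 100 ug/mL in this assay, at which 2 of the 2 values shown sit. Compound 3 `Cc1nc(-c2cccnc2)sc1-c1nnc(-c2ccc(O)cc2)o1` carries the change (4-hydroxyphenyl in place of 2-methylphenyl on an aromatic carbon). Among the measured compounds shown here, no measured step resembles this change, so no direction can be read from it. Compound 3 is expected to give 100 ug/mL, within 50 ug/mL to 200 ug/mL. The estimated step of a number no higher from compound 2 to compound 3 (the limit leaves the size open) is expected to stay within the scatter.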

Compound 3, half-maximal cytotoxic concentration: > 100 ug/mL
Compound 3 gave a limit, no number; the forecaster's own chance of this, stated with the estimate: 75%; the middle value sits exactly at the limit.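

No step can be read among compound 1, compound 2 and compound 3, as each stops at a limit in this assay: the limit of > 100 ug/mL in this assay, at which 3 of the 3 values shown sit.

The compounds shown leave open where the actual cytotoxic concentration of each lies, and whether any of these group changes alters it.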